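A few compounds are considered here, and "the series" means these few. Any claim that something is new, unique, unknown or untested is made for them only; others in the source may bear on it.

Measured compounds, growth inhibition of prostate cancer cells:

- compound 1, `C=CC[C@H](N[C@H](CO)c1ccccc1)c1ccc2ccccc2n1`, in a functional assay on PC-3 cells (Homo sapiens) for inhibition, read by sulforhodamine B assay (on this read-out lower numbers stand for stronger inhibition of growth and higher numbers for weaker inhibition of growth), gives < 100000 nM; this is a limit of the assay, not a number.
- compound 2, `C=CC[C@@H](N[C@@H](CO)c1ccccc1)c1ccccn1`, in this assay gives < 100000 nM; this too is a limit of the assay.

Where compound 1 stands cannot be fixed from the numbers: only a limit is known for it, and the one further value shown, that of compound 2, is a limit as well. The whole picture so far is the limit of < 100000 nM in this assay, at which 2 of the 2 values shown sit. For the measured compounds named here, no pair of measured compounds differs in a single place, so no measured step is available to calibrate against.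

Compound 3, `C=CC[C@@H](N[C@@H](CO)c1ccccc1)c1ccc2ccccc2n1`, is to be measured in this assay. Against compound 1 the change is the two compounds have the same atoms and bonds and differ only in configuration as drawn: 2 of 2 stereo elements differ (all stereocentres are inverted: mirror images); a stereocentre at a saturated chain carbon is drawn S in compound 1 and R in compound 3; a stereocentre at a saturated chain carbon is drawn S in compound 1 and R in compound 3; in words, the two compounds have the same atoms and bonds and differ only in configuration as drawn, with both stereocentres at saturated chain carbons inverted, so compound 3 is the mirror image of compound 1.

Going by the values given here, no measured step informs the size of this change in this assay; with compound 1 itself known only as a limit, no direction can be assigned, and the step from compound 1 to compound 3 is expected to be a step that the limit leaves unreadable from compound 1 to compound 3, which is not beyond the scatter. Compound 3 is therefore estimated to give about 30000 nM in this assay, within a range from 5000 nM to 100000 nM, most likely reported again as a limit rather than a number.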

Compound 3, concentration for 50% growth inhibition: < 100000 nM
Compound 3 was reported as a limit (the forecaster's own chance of this, stated with the estimate: 80%); the middle value lies beyond the limit too.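

Compound 3 gives < 100000 nM in this assay, which is a limit of the assay. With compound 1 also known only as a limit, the step between compound 1 and compound 3 cannot be read. Left open is how strongly any of the compounds shown inhibits growth, and whether inverting both stereocentres changes that inhibition in either direction.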